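Opening a ring-bound anilide: from hydroxy to ethoxyethylamino

This account rests on a few compounds, and the source may have more. Where it says the series, first, only, none or still open, it means among the compounds named here.

Compound 1 `CC(C)(C)C(=O)CN1C(=O)N(CC(=O)Nc2cccc(O)c2)N=C(C2CCCCC2)c2ccccc21`: 27.5 nM
Compound 2 `CNc1cccc(NC(=O)CN2N=C(c3ccccc3)c3ccccc3N(CC(=O)C(C)(C)C)C2=O)c1`: 132 nM

In a functional assay on stomach for binding affinity to Gastrin/cholecystokinin type B receptor (Rattus norvegicus) (a higher number here means weaker binding, a lower number tighter binding), compound 1 gives 27.5 nM, the lowest of the two numbers recorded. Compound 2 gives 132 nM in this assay, a gap beyond the usual scatter; the two compounds differ in more than one place, so their values are simply shown side by side. Compound 3 `CCOCCNc1cccc(NC(=O)CN2N=C(C3CCCCC3)c3ccccc3N(CC(=O)C(C)(C)C)C2=O)c1` is not yet measured. It differs from compound 1 by (2-ethoxyethyl)amino in place of hydroxy on an aromatic carbon. Among the compounds with values here, with no single-point step recorded to guide it, the step from compound 1 to compound 3 is expected to be a modest weakening, a 2.2-fold higher number from compound 1 to compound 3 (0.34 log units; beyond the scatter). Compound 3 is therefore estimated at 60 nM, within a range from 15 nM to 250 nM.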

Compound 3, dissociation constant: 105 nM
Compound 3: the middle estimate sits 1.8-fold (0.24 log units) below what was measured, within the range that was stated.
By their numbers in this assay, from the lowest: compound 1; then compounds 3 and 2 (each within the scatter of the next).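

Within the data shown here, putting (2-ethoxyethyl)amino in place of hydroxy on this aromatic carbon gives a 3.8-fold higher number from compound 1 to compound 3 (0.58 log units; beyond the scatter) in this assay and is the first single-place step read at this position. The change costs only modest affinity, so the position accepts a far larger group while binding is kept. Nothing measured here explains the loss.

The step changes the linking atom and adds the chain together, so it cannot show which of the two accounts for the loss. As far as these compounds go, how a plain amino group or a carboxylic acid would read at this position on the same core remains open.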